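Swapping 4-Bromophenyl for 2,6-Dichlorophenyl

The source may hold more compounds than are shown below. What is called first, only, known or untested is meant among the compounds shown, and "the series" means these compounds.

Of the compounds shown here, two sharing one core have been measured so far. In an ADME assay on Vero cells (Chlorocebus sabaeus) for inhibition (a higher number here means that more compound is tolerated, a lower number that less compound is tolerated), compound 1 (`COc1ccc(/C=C2\CCC/C(=C\c3ccccc3)C2=O)cc1`) gives 291000 nM and compound 2 (`COc1ccc(/C=C2\CCC/C(=C\c3ccc(Br)cc3)C2=O)cc1`) gives 250000 nM on the same test. Compound 2 therefore stands within the scatter of compound 1, and the two cannot be ranked.

Compound 3 (`COc1ccc(/C=C2\CCC/C(=C\c3c(Cl)cccc3Cl)C2=O)cc1`) differs from compound 2 by one change, counted as 2,6-dichlorophenyl in place of 4-bromophenyl on a double-bonded chain carbon bound to a double-bonded ring carbon in the structures: 2,6-dichlorophenyl in place of 4-bromophenyl on a double-bonded chain carbon bound to a double-bonded ring carbon.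

Among the compounds with values here, only one measured step bears on this change. Bromo in place of hydrogen on an aromatic carbon gave a 1.2-fold lower number from compound 1 to compound 2 (0.07 log units; within the scatter) and so stayed within the scatter. Within the data shown here, no chlorine-bearing compound has been measured yet, so this evidence is thin and the range must stay wide. Among the measured compounds shown here, with compound 1 and compound 2 as the only guide, no step beyond the scatter is expected in either direction. The estimate amounts to an expected 1.1-fold lower number from compound 2 to compound 3 (0.06 log units; within the scatter) on this measure. For compound 3 the estimated value in this assay is about 220000 nM with an expected range from 90000 nM to 450000 nM at its two ends.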

Compound 3, half-maximal cytotoxic concentration: 232000 nM
Estimate against measurement, compound 3: 1.1-fold (0.02 log units) below; low and high end bracket the measured number.
By their numbers in this assay, from the lowest: compounds 3, 2 and 1 (each within the scatter of the next).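

Within the data shown here, the earlier pair tested only a single bromo on the ring, whereas 2,6-dichlorophenyl carries two chlorine atoms in place of one bromine, on a double-bonded chain carbon bound to a double-bonded ring carbon. Even so, this assay gives a 1.1-fold lower number from compound 2 to compound 3 (0.03 log units; within the scatter), and measured against plain phenyl the same place gives a 1.3-fold lower number from compound 1 to compound 3 (0.10 log units; within the scatter), so both steps stay within the scatter and the three compounds cannot be ranked. This shows that, among these three groups, neither the kind of halogen nor the number of halogen atoms on this ring separates the compounds in this test, though no measurement is at hand that could account for this.

From the compounds shown here alone, all three groups at this position are phenyl rings, either plain or carrying halogen, so it remains open whether a ring bearing an amine or a carboxylic acid, or a longer chain in place of the ring, would move the number beyond the scatter. The other side of the shared core stays the same throughout, so these compounds also leave open whether a change there would behave in the same way.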